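Benzyl in Place of Hydrogen on the Ring Nitrogen

The source may report more compounds than this note shows. Statements on the series, on what has been measured and on what is new or still open speak of the compounds shown alone.

Measured in a functional assay on Bel7402/5-FU cells (Homo sapiens) for antiproliferative activity, read by MTT assay, with a stated time of 72 h; a higher number here means a weaker inhibitor, a lower number a stronger inhibitor:
compound 1 `C=C1C(=O)O[C@H]2[C@H]1CC/C(COC(=O)CCC(=O)NCCCCCCNC(=O)Cn1cc(F)c(=O)[nH]c1=O)=C\CC[C@@]1(C)O[C@@H]21` gives a limit of the assay, > 20000 nM.
compound 2 `C=C1C(=O)O[C@H]2[C@H]1CC/C(COC(=O)CCC(=O)N1CCN(C(=O)Cn3cc(F)c(=O)[nH]c3=O)CC1)=C\CC[C@@]1(C)O[C@@H]21` gives a limit of the assay, > 20000 nM.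
compound 3 `C=C1C(=O)O[C@H]2[C@H]1CC/C(COC(=O)CCC(=O)NCCCCCCNC(=O)Cn1cc(F)c(=O)n(Cc3ccccc3)c1=O)=C\CC[C@@]1(C)O[C@@H]21` gives 16200 nM.

Compound 1 and compound 3 differ in one place, (benzyl in place of hydrogen on an aromatic nitrogen), and the step is an at least 1.2-fold lower number from compound 1 to compound 3 (0.09 log units; that floor lies within the scatter). That floor rests on (the limit of > 20000 nM in this assay, at which 2 of the 3 values shown sit), so the true size of the step is not settled by these two values. How the core of compound 2 differs from the core of compound 1 is not broken down here.

Compound 4 `C=C1C(=O)O[C@H]2[C@H]1CC/C(COC(=O)CCC(=O)N1CCN(C(=O)Cn3cc(F)c(=O)n(Cc4ccccc4)c3=O)CC1)=C\CC[C@@]1(C)O[C@@H]21` is not yet measured. It differs from compound 2 by benzyl in place of hydrogen on an aromatic nitrogen, the same change as from compound 1 to compound 3, with the two place descriptions identical word for word.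

For compound 4 a step of an at least 1.1-fold lower number from compound 2 to compound 4 (0.04 log units; that floor lies within the scatter) is expected, resting on the earlier step of an at least 1.2-fold lower number from compound 1 to compound 3 (0.09 log units; that floor lies within the scatter) and on the fact that compound 2 sits at the limit of > 20000 nM in this assay, at which 2 of the 3 values shown sit. The estimate for compound 4 is 18000 nM, expected between 8000 nM and 40000 nM, with a real chance that only a limit is reported.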

Compound 4, half-maximal inhibitory concentration: > 20000 nM
Compound 4: a limit, no number (the forecaster's own chance of this, stated with the estimate: 50%); middle value at least 1.1-fold (0.04 log units) away from the limit.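

In this assay compound 4 gives > 20000 nM as a limit of the assay, not a number. With compound 2 also at a limit, no step can be read from compound 2 to compound 4: the limit of > 20000 nM in this assay, at which 3 of the 4 values shown sit. The compounds shown leave open whether benzyl in place of hydrogen on an aromatic nitrogen changes antiproliferative activity by any real amount.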